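A nitro group returns: from compound 3 to compound 4

A few compounds are considered here, and "the series" means these few. Any claim that something is new, unique, unknown or untested is made for them only; others in the source may bear on it.

Compound 1 `COc1cc(C(=O)c2cn(-c3ccccc3)cc2-c2ccc(N)cc2)cc(OC)c1OC` gives 9 nM
Compound 2 `COc1cc(C(=O)c2cn(-c3ccccc3[N+](=O)[O-])cc2-c2ccccc2)cc(OC)c1OC` gives 5000 nM
Compound 3 `COc1ccccc1-n1cc(C(=O)c2cc(OC)c(OC)c(OC)c2)c(-c2ccccc2)c1` gives 150 nM

These values come from a functional assay on MCF7 cells (Homo sapiens) for cytotoxicity, read by MTT assay, with a stated time of 96 h (on this read-out lower numbers stand for stronger inhibition and higher numbers for weaker inhibition), where compound 3 is the second highest of the three numbers. The move to compound 4 `COc1cc(C(=O)c2cn(-c3ccc([N+](=O)[O-])cc3)cc2-c2ccccc2)cc(OC)c1OC` is 4-nitrophenyl in place of 2-methoxyphenyl on an aromatic nitrogen, with 4-nitrophenyl in place of 2-methoxyphenyl on an aromatic nitrogen. Going by the values given here, one measured step bears on it: a 33-fold lower number from compound 2 to compound 3 (1.52 log units; beyond the scatter), a large step with methoxy in place of nitro on an aromatic carbon. Compound 4 reverses that exchange, though it does not carry its nitro group where compound 2 does, so only part of that step is expected to carry over. The expected step, towards a higher number, is a 6.7-fold higher number from compound 3 to compound 4 (0.82 log units; beyond the scatter). For compound 4 the estimated value is 1000 nM, with an expected range from 200 nM to 5000 nM.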

Compound 4, half-maximal inhibitory concentration: 4000 nM
The estimate for compound 4 lay 4.0-fold (0.60 log units) below the measured number, within the range that was stated.
By their numbers in this assay, from the lowest: compound 1; then compound 3; then compounds 4 and 2 (each within the scatter of the next).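

In this assay, 4-nitrophenyl in place of 2-methoxyphenyl on the aromatic nitrogen gives a 27-fold higher number from compound 3 to compound 4 (1.43 log units; beyond the scatter), so the nitro penalty seen earlier is not confined to the 2-nitrophenyl compound. Between the two nitrophenyl groups the shift is only a 1.3-fold lower number from compound 2 to compound 4 (0.10 log units; within the scatter), which leaves compound 2 and compound 4 indistinguishable at this position. Nothing available explains this result.

Still open, as far as these compounds go, is whether 4-methoxyphenyl on the aromatic nitrogen would keep the lower number of compound 3, and whether an amine in place of the nitro group would restore activity.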